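Changing the Ring Group on Compound 2

The source may hold more compounds than are shown below. What is called first, only, known or untested is meant among the compounds shown, and "the series" means these compounds.

Measured so far:
- compound 1 (`CC(C)C(/C=C1\NC(=O)NC1=O)c1ccc(-c2ccc3cccc(F)c3c2)[nH]c1=O`) gives > 3 h (a limit of the assay, not a number)
- compound 2 (`CC(C)C(c1ccc(-c2ccc3cccc(F)c3c2)[nH]c1=O)C1SC(=O)NC1=O`) gives 1.87 h

Within the data shown here, in an ADME assay on microsomes from liver (Homo sapiens) for metabolic stability (a higher number here means that the compound lasts longer, a lower number that the compound disappears faster), compound 2 gives 1.87 h and this is the only true number so far. Compound 1 shows > 3 h and this is a limit, not a number.

The next compound is compound 3 (`C/C(=C1/OC(=O)NC1=O)C(c1ccc(-c2ccc3cccc(F)c3c2)[nH]c1=O)C(C)C`), which is compound 2 with one group exchanged: a group of 9 heavy atoms (5 carbon, 1 nitrogen, 3 oxygen; one five-membered non-aromatic ring with 2 hetero atoms) in place of a group of 7 heavy atoms (3 carbon, 1 nitrogen, 2 oxygen, 1 sulfur; one five-membered non-aromatic ring with 2 hetero atoms), on a saturated chain carbon bound to an aromatic carbon and a saturated chain carbon. The 2,4-dioxo-1,3-thiazolidin-5-yl group leaves, and the rest of the molecule stays the same.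

Among the measured compounds shown here, only one measured step bears on this change. It also exchanges one ring group for another at the same place. That step is an at least 1.6-fold lower number from compound 1 to compound 2 (0.20 log units; that floor lies within the scatter) and it is only a floor. Going by these compounds, its true size stays open because of the limit of > 3 h in this assay, at which 1 of the 2 values shown sits, in compound 1. With so little to go on, no step beyond the scatter is expected in either direction. The expected step is a 1.2-fold higher number from compound 2 to compound 3 (0.07 log units; within the scatter) and it would be too small to read as a real change. Compound 3 is estimated at 2.2 h (expected range 1.1 h to 4.4 h).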

Compound 3, half-life: > 3 h
Compound 3 ended at the assay's limit; the forecaster's own chance of this, stated with the estimate: 25%; at least 1.3-fold (0.13 log units) between middle value and limit.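

In this assay compound 3 gives > 3 h, which is a limit of the assay and not a number. Among these compounds, exchanging the 2,4-dioxo-1,3-thiazolidin-5-yl group for the new ring group at this saturated chain carbon gives an at least 1.6-fold higher number from compound 2 to compound 3 (0.20 log units; that floor lies within the scatter), so the group that holds sulfur is now the only one of the three ring groups with a true number, yet this floor lies within the scatter and does not establish a real gap. The step between compound 1 and compound 3 cannot be read, and the true size of the other steps stays open because of the ceiling of the assay: the limit of > 3 h in this assay, at which 2 of the 3 values shown sit.

Nothing shown tells apart the loss of the sulfur atom from the gain of a double bond outside aromatic rings, so neither can yet be linked to the longer half-life. Going by these compounds, how a group without a ring, such as a carboxylic acid or a simple amine, would behave at this saturated chain carbon also stays open.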